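The source may hold more compounds than are shown below. What is called first, only, known or untested is meant among the compounds shown, and "the series" means these compounds.

Compound 1 `Cc1ccsc1CN[C@@H]1C[C@H]2C[C@@H]([C@H]1C)C2(C)C` is the starting point. In an ADME assay on MDCK cells (Canis lupus familiaris) for cytotoxicity, read by microscopy, with a stated time of 48 h (a higher number here means that more compound is tolerated, a lower number that less compound is tolerated), compound 1 gives 10000 nM, the second highest of the three numbers measured. Compound 3 `CCCc1csc(CN[C@@H]2C[C@H]3C[C@@H]([C@H]2C)C3(C)C)c1` gives 12500 nM, a value that lies within the scatter of compound 1, so the two cannot be told apart. Among the compounds with values here, compound 2 `Cc1ccc(CN[C@@H]2C[C@H]3C[C@@H]([C@H]2C)C3(C)C)s1` gives 780 nM, and the one measured step with a single change, a 13-fold lower number from compound 1 to compound 2 (1.11 log units; beyond the scatter), shows that moving a methyl group around the five-membered aromatic ring can shift tolerance a long way.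

Compound 4 `C[C@H]1[C@H](NCc2sccc2C2CCCC2)C[C@H]2C[C@@H]1C2(C)C` differs from compound 1 in one place: cyclopentyl in place of methyl on an aromatic carbon. Within the data shown here, no measured step covers a change of this kind; the only comparison with a larger chain on the ring, compound 3 against compound 1, shows two values within the scatter of each other. The expectation is therefore a step of a 1.4-fold lower number from compound 1 to compound 4 (0.15 log units; within the scatter), small and not clearly beyond the scatter. Compound 4 is estimated at 7000 nM, with a range from 2500 nM to 20000 nM.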

Compound 4, minimum cytotoxic concentration: 12500 nM
Estimate against measurement, compound 4: 1.8-fold (0.25 log units) below; low and high end bracket the measured number.
By their numbers in this assay, from the lowest: compound 2; then compounds 1, 3 and 4 (each within the scatter of the next).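

At the ring carbon two ring bonds from the ring sulfur, cyclopentyl can stand in place of methyl in this assay with no step beyond the usual scatter, as a 1.3-fold higher number from compound 1 to compound 4 (0.10 log units; within the scatter) shows. This position therefore accepts five carbon atoms and a non-aromatic ring in place of a single carbon, while the step of a 13-fold lower number from compound 1 to compound 2 (1.11 log units; beyond the scatter) remains the only large one, and it comes from where the methyl sits on the ring, not from the size of the group.

From the compounds shown here alone, whether an amine, a carboxylic acid or a longer chain such as hexyl would leave the number as little changed at this position stays open. Also open, going by these compounds, is whether cyclopentyl would give a number like that of compound 2 if placed where compound 2 carries its methyl. No measurement here explains why the change from methyl to cyclopentyl makes so little difference.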